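A few compounds are considered here, and "the series" means these few. Any claim that something is new, unique, unknown or untested is made for them only; others in the source may bear on it.

The three measured compounds in a physicochemical assay for solubility, at pH 7.4; on this read-out lower numbers stand for lower solubility and higher numbers for higher solubility:

Compound 1, `Cc1csc(-c2cc(NC(=O)c3ccc(OCc4ccccn4)cc3)c(C)cc2C)n1`, gives < 1000 nM, which is a limit of the assay, not a number.
Compound 2, `Cc1cc(C)c(-c2ccccn2)cc1NC(=O)c1ccc(OCc2ccccn2)cc1`, gives < 1000 nM, again a limit of the assay.
For the measured compounds named here, compound 3, `Cc1cc(C)c(-c2cccnc2)cc1NC(=O)c1ccc(OCc2ccccn2)cc1`, gives 9000 nM, the only true number among the three.

Compound 3 therefore stands at the top of what is shown. Both steps leading to it are sizeable: an at least 9.0-fold higher number from compound 1 to compound 3 (0.95 log units; beyond the scatter) and an at least 9.0-fold higher number from compound 2 to compound 3 (0.95 log units; beyond the scatter), each read against (the limit of < 1000 nM in this assay, at which 2 of the 3 values shown sit). The step from compound 1 to compound 2 is a step that the two limits leave unreadable from compound 1 to compound 2.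

Compound 4, `Cc1cc(C)c(-c2ccc(N)nn2)cc1NC(=O)c1ccc(OCc2ccccn2)cc1`, is not yet measured. It differs from compound 3 in one place: 6-aminopyridazin-3-yl in place of pyridin-3-yl on an aromatic carbon. Going by the values given here, no measured step covers a change of this kind; the measured steps swap one six-membered or five-membered ring for another, and none puts an amino group or a second ring nitrogen onto the ring at this position. The expectation for compound 4 therefore rests on compound 3 alone, with no clear direction from the data, and a change within the scatter or somewhat upward seems most plausible.

Compound 4 is expected to give 15000 nM, within 4000 nM to 60000 nM, so that the estimated step from compound 3 is a 1.7-fold higher number from compound 3 to compound 4 (0.22 log units; within the scatter).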

Compound 4, solubility: 6000 nM
Estimate against measurement, compound 4: 2.5-fold (0.40 log units) above; measured number inside the range.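

In this assay, 6-aminopyridazin-3-yl in place of pyridin-3-yl gives a 1.5-fold lower number from compound 3 to compound 4 (0.18 log units; within the scatter), so this position accepts a ring with a second hetero atom and an added amino group with no change that this read-out can resolve. The ring type alone does not set the outcome, however: pyridin-2-yl is also a six-membered aromatic ring, yet replacing it with 6-aminopyridazin-3-yl gives an at least 6.0-fold higher number from compound 2 to compound 4 (0.77 log units; beyond the scatter), and replacing 4-methyl-1,3-thiazol-2-yl gives an at least 6.0-fold higher number from compound 1 to compound 4 (0.77 log units; beyond the scatter). Both of those steps are minimum sizes, and the step between compound 1 and compound 2 cannot be read, as each of them rests on a limit of the assay rather than a number: the limit of < 1000 nM in this assay, at which 2 of the 4 values shown sit.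

As far as these compounds go, what a plain pyridazin-3-yl without the amino group would give stays open, so the effects of the extra ring nitrogen and of the amino group cannot yet be told apart. Also open, from the compounds shown here alone, is how a methylamino group, a hydroxyl group or a carboxylic acid in place of that amino group would read in this assay.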